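The source may hold more compounds than are shown below. What is called first, only, known or untested is meant among the compounds shown, and "the series" means these compounds.

Three compounds have numbers in an in vitro assay on Sf9 cells for inhibition of RAC-alpha serine/threonine-protein kinase (Homo sapiens), read by AlphaScreen, with a stated time of 20 min; on this read-out lower numbers stand for stronger inhibition and higher numbers for weaker inhibition. Compound 1 `Nc1ccc(-n2c(-c3cccnc3N)nc3cccnc32)cc1` gives 740 nM in this assay. Compound 2 `COc1ccccc1Cn1c(-c2cccnc2N)nc2cccnc21` gives 58000 nM, and compound 3 `Nc1ncccc1-c1nc2cc(-c3cccnc3)cnc2n1-c1ccc(CNC(=O)c2ccccc2)cc1` gives 8 nM. Compound 1 thus stands second highest of the three numbers, between compound 2 and compound 3, and both gaps to compound 1 lie beyond the scatter.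

Compound 4 `Nc1ncccc1-c1nc2cccnc2n1-c1ccc(CNC(=O)C2CCCCC2)cc1` has not yet been measured in this assay. It differs from compound 1 in one place: ((cyclohexylcarbonyl)amino)methyl in place of amino on an aromatic carbon. Among the compounds with values here, no measured pair isolates exactly this change. Compound 3, which carries an amide-bearing group at the same place alongside a second change on the core, shows a far lower number than compound 1, so the two values together point the same way as the change from compound 1 to compound 4, without a clean step to lean on.

On that basis the step of a 12-fold lower number from compound 1 to compound 4 (1.09 log units; beyond the scatter) is expected to lower the number beyond the scatter. Compound 4 is estimated at 60 nM, with a range from 15 nM to 300 nM.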

Compound 4, half-maximal inhibitory concentration: 250 nM
Beside the measured number, compound 4's estimate is 4.2-fold (0.62 log units) below it; the range from low to high includes it.
By their numbers in this assay, from the lowest: compound 3; then compound 4; then compound 1; then compound 2.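

In this assay, within the data shown here, ((cyclohexylcarbonyl)amino)methyl in place of amino on the aromatic carbon para to a large group gives a 3.0-fold lower number from compound 1 to compound 4 (0.47 log units; beyond the scatter), the first step that isolates a change at this position. The position therefore takes a much larger group carrying a six-membered non-aromatic ring of carbon only without the number rising, although the gain is modest. Nothing available accounts for the size of this step.

Still open, from the compounds shown here alone, is which part of the entering group carries the step: the cyclohexyl ring, the carbonyl or the methylene link. An aminomethyl group or a carboxylic acid at the same place would help separate these parts from the overall change.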